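The source may hold more compounds than are shown below. What is called first, only, known or untested is meant among the compounds shown, and "the series" means these compounds.

For the measured compounds named here, in a functional assay on G-361 cells (Homo sapiens) for cytotoxicity, read by MTT assay, with a stated time of 3 days (on this read-out lower numbers stand for stronger inhibition and higher numbers for weaker inhibition), compound 2 `N#Cc1c(Nc2ccccc2)nc(SCc2nc3ccccc3[nH]2)nc1-c1ccccc1` gives 2.4 nM, the lowest of the three numbers known here. Compound 1 `N#Cc1c(Cl)nc(SCc2nc3ccccc3[nH]2)nc1-c1ccccc1` gives 12.5 nM, and compound 3 `N#Cc1c(Nc2ccccn2)nc(SCc2nc3ccccc3[nH]2)nc1-c1ccccc1` gives 8.9 nM. Compound 4 `CN1CCN(c2nc(SCc3nc4ccccc4[nH]3)nc(-c3ccccc3)c2C#N)CC1` differs from compound 2 in one place: 4-methylpiperazin-1-yl in place of anilino on an aromatic carbon. Going by the values given here, two measured steps concern this same position and bear on the change. First, a 5.2-fold lower number from compound 1 to compound 2 (0.72 log units; beyond the scatter). Second, a 3.7-fold higher number from compound 2 to compound 3 (0.57 log units; beyond the scatter). The third step, a 1.4-fold lower number from compound 1 to compound 3 (0.15 log units; within the scatter), shows that a nitrogen-linked group at this carbon is not by itself enough to reach the number of compound 2, since the pyridin-2-yl variant stays near compound 1. The anilino group of compound 2 thus stands alone in giving the lowest number, and its removal is expected to cost something. For compound 4 a modest rise is therefore expected, a 5.0-fold higher number from compound 2 to compound 4 (0.70 log units; beyond the scatter), placing it nearer compound 3 and compound 1 than compound 2. Compound 4 is estimated at 12 nM, within a range from 4 nM to 40 nM.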

Compound 4, half-maximal inhibitory concentration: 14.7 nM
Compound 4: the middle estimate sits 1.2-fold (0.09 log units) below what was measured; the range from low to high includes it.
By their numbers in this assay, from the lowest: compound 2; then compounds 3, 1 and 4 (each within the scatter of the next).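

The anilino group of compound 2 is not matched by 4-methylpiperazin-1-yl in this assay, with a 6.1-fold higher number from compound 2 to compound 4 (0.79 log units; beyond the scatter). The new group cannot be told apart from the other two at this carbon, with a 1.7-fold higher number from compound 3 to compound 4 (0.22 log units; within the scatter) and a 1.2-fold higher number from compound 1 to compound 4 (0.07 log units; within the scatter), both within the scatter. Among the four compounds, only the anilino compound now stands apart, and nothing available here explains why.

This change replaces the aromatic ring and the hydrogen-bond donor together, so the compounds shown leave open which of the two matters. A methyl(phenyl)amino group, which keeps the phenyl ring without the nitrogen hydrogen, or a cyclohexylamino group, which keeps that hydrogen without the aromatic ring, would separate them at this carbon.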